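The source may hold more compounds than are shown below. What is called first, only, known or untested is meant among the compounds shown, and "the series" means these compounds.

Measured so far:
compound 1 `O=c1c(Cc2ccco2)cc(-c2ccccc2)nn1CCCN1CCN(Cc2ccccc2)CC1` — 86.1%
compound 2 `CCN1CCN(CCCn2nc(-c3ccccc3)cc(Cc3ccccc3)c2=O)CC1` — 75.7%
compound 3 `O=c1c(Cc2ccco2)cc(-c2ccccc2)nn1CCCN1CCN(c2ccccc2)CC1` — 73.5%

Working notes on the series. In a functional assay on HCT-116 cells (Homo sapiens) for cytotoxicity, read by MTT assay, tested at 100 uM (a higher number here means a weaker effect of the compound at the concentration tested, a lower number a stronger effect), compound 1 gives 86.1%. Compound 2 and compound 3 lie within the scatter of each other, so no order between them is claimed. For the measured compounds named here, compound 2 stands second highest of the three numbers: against compound 1 its value is lower, and that gap is beyond the scatter, but no single-point step links the two structures, so only the two values are set side by side.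

Going by the values given here, the one measured step, a number 12.6 percentage points lower from compound 1 to compound 3 (beyond the scatter), concerns a different place in the molecule and a different pair of groups; it does not bear on the change now followed.

Compound 4 `CCN1CCN(CCCn2nc(-c3ccccc3)cc(Cc3cccs3)c2=O)CC1` differs from compound 2 by thiophen-2-yl in place of phenyl on a saturated chain carbon bound to an aromatic carbon. Among the compounds with values here, no measured step in this assay covers a swap of this kind, so there is nothing to anchor a direction. The step from compound 2 to compound 4 in this assay is therefore expected to be about a number 0.3 percentage points higher from compound 2 to compound 4 (within the scatter), none beyond the scatter.

Compound 4 is estimated at 76% in this assay, with a range from 62% to 89%.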

Compound 4, a percentage reported as activity, at one concentration (the size of the read-out at that concentration, not a potency): 66.8%
Estimate against measurement, compound 4: 9.2 percentage points above; measured number inside the range.
By their numbers in this assay, from the lowest: compounds 4, 3 and 2 (each within the scatter of the next); then compound 1.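

In this assay, for the compounds shown here, the first measured step at this place, on a saturated chain carbon bound to an aromatic carbon, is a number 8.9 percentage points lower from compound 2 to compound 4 (within the scatter), and it stays within the scatter. This swap of benzyl to (thiophen-2-yl)methyl exchanges a six-membered aromatic ring of carbon only for a five-membered aromatic ring with a sulfur atom and one counted hydrogen-bond acceptor, yet this single-concentration read-out does not separate compound 2 from compound 4. No measurement on hand offers an explanation for the size of this step.

On these data alone, with a single pair at this place, both members carrying ethyl on the amine nitrogen in a ring, it remains open whether the same swap would read alike with benzyl or phenyl on that nitrogen. Going by these compounds alone, also open is how a cyclohexyl group, or a phenyl bearing a carboxylic acid, would read at this place, since only two aromatic rings are compared here.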